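This account rests on a few compounds, and the source may have more. Where it says the series, first, only, none or still open, it means among the compounds named here.

Measured in a functional assay on MDA-MB-435 cells (Homo sapiens) for cytotoxicity, read by MTT assay, with a stated time of 72 h; a lower number here means a stronger inhibitor, a higher number a weaker inhibitor:
- Compound 1 `Nc1cccc(Nc2c(C(=O)NCc3ccc(F)cc3)nc(Br)c3cccnc23)c1`: 8000 nM
- Compound 2 `Nc1ccc(Nc2c(C(=O)NCc3ccc(F)cc3)nc(Br)c3cccnc23)cc1`: 7000 nM

Compound 2 stands level with compound 1, since a 1.1-fold lower number from compound 1 to compound 2 (0.06 log units; within the scatter). Compound 3 `CN(C)CCCNc1c(C(=O)NCc2ccc(F)cc2)nc(Br)c2cccnc12` brings a larger change: 3-(dimethylamino)propyl in place of 4-aminophenyl on a nitrogen on an aromatic ring. In short, 3-(dimethylamino)propyl takes the place of 4-aminophenyl on a nitrogen on an aromatic ring. For the measured compounds named here, the single measured step only swaps 3-aminophenyl for 4-aminophenyl, so no measured step covers this replacement. With so little evidence, no step beyond the scatter is expected in this assay, though the uncertainty is wide. The expected result is a 1.4-fold lower number from compound 2 to compound 3 (0.15 log units; within the scatter). The estimate for compound 3 is 5000 nM, with an expected range of 1200 nM to 20000 nM.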

Compound 3, half-maximal inhibitory concentration: 7000 nM
Beside the measured number, compound 3's estimate is 1.4-fold (0.15 log units) below it; measured number inside the range.
By their numbers in this assay, from the lowest: compounds 2, 3 and 1 (each within the scatter of the next).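

In this assay, putting 3-(dimethylamino)propyl in place of 4-aminophenyl on the nitrogen gives no change at the digits printed from compound 2 to compound 3 (within the scatter) and putting it in place of 3-aminophenyl gives a 1.1-fold lower number from compound 1 to compound 3 (0.06 log units; within the scatter) in this comparison. Across these three compounds, then, an open chain with no ring sits level with either aminophenyl group at this position. No supporting measurement bears on why the numbers stay level.

Still open, as far as these compounds go, is whether a shorter or longer chain ending in dimethylamino would move the number beyond the scatter. A carboxylic acid or a morpholine at the chain's end is also an open case.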